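Oxazolyl in place of methanesulfonamido on the shared core

A few compounds are considered here, and "the series" means these few. Any claim that something is new, unique, unknown or untested is made for them only; others in the source may bear on it.

Compound 3 `CS(=O)(=O)Nc1cccc2c1CCC2c1ncc[nH]1` stands at a limit: in a functional assay on CHO cells for agonist activity at Alpha-1D adrenergic receptor (Homo sapiens), read by FLIPR and calcium flux (on this read-out higher numbers stand for an effect only at larger amounts of compound and lower numbers for an effect already at smaller amounts), compound 3 gives > 10000 nM, which is a limit of the assay and not a number. Compound 2 `COc1cccc2c1CCC2c1ncc[nH]1` also gives > 10000 nM, again a limit. Compound 1 `c1cc(-c2ccn[nH]2)c2c(c1)C(c1ncc[nH]1)CC2` gives 336 nM. The series therefore rests on (the limit of > 10000 nM in this assay, at which 2 of the 3 values shown sit). The change to compound 4 `c1cc(-c2ncco2)c2c(c1)C(c1ncc[nH]1)CC2` is 1,3-oxazol-2-yl in place of methanesulfonamido on an aromatic carbon. The measured steps that bear on it run the other way: an at least 29-fold higher number from compound 1 to compound 2 (1.47 log units; beyond the scatter) and an at least 29-fold higher number from compound 1 to compound 3 (1.47 log units; beyond the scatter), both large, while a step that the two limits leave unreadable from compound 2 to compound 3. The entering 1,3-oxazol-2-yl, a five-membered aromatic ring with 2 hetero atoms, resembles the 1H-pyrazol-5-yl of compound 1, which gives 336 nM, more than the methanesulfonamido of compound 3. A large downward step is therefore expected, an at least 6.6-fold lower number from compound 3 to compound 4 (0.82 log units; beyond the scatter). Compound 4 is estimated at 1500 nM, between 300 nM and 8000 nM.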

Compound 4, half-maximal effective concentration: 1390 nM
For compound 4 the middle estimate is 1.1-fold (0.03 log units) above the measured one; the range from low to high includes it.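

In this assay, a five-membered aromatic ring with 2 hetero atoms on this aromatic carbon is not confined to compound 1, as shown by an at least 7.1-fold lower number from compound 3 to compound 4 (0.85 log units; beyond the scatter) and by an at least 7.1-fold lower number from compound 2 to compound 4 (0.85 log units; beyond the scatter). Both steps start from a limit of the assay, so they fix only a minimum size: the limit of > 10000 nM in this assay, at which 2 of the 4 values shown sit. The two rings are not equivalent here, with a 4.1-fold higher number from compound 1 to compound 4 (0.62 log units; beyond the scatter).

The compounds shown leave open whether the placement of the hetero atoms in the ring accounts for that gap. They also leave open how an amine, a carboxylic acid or a phenyl ring would behave on this carbon.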